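The compounds below may be only part of what the source reports. "The series", "measured", "known", "first", "only" and "open" are said of these compounds alone.

Measured in a functional assay on cells (T-cell, Homo sapiens) for inhibition, read by scintillation counting and thymidine incorporation, with stated times of 60 min and 3 days; on this read-out lower numbers stand for stronger inhibition and higher numbers for weaker inhibition:
- compound 1 `COc1ccc(-c2cc3c(N[C@H](CO)CC(C)C)c(C(N)=O)cnn3c2)cn1`: 190 nM
- compound 2 `C[C@@H](O)[C@@H](CO)Nc1c(C(N)=O)cnn2cc(-c3ccccc3)cc12`: 70 nM
- compound 3 `C[C@H](O)[C@H](CO)Nc1c(C(N)=O)cnn2cc(-c3ccccc3)cc12`: 2000 nM

Compound 3 gives the highest number of the three. Compound 4 `C[C@H](O)[C@@H](CO)Nc1c(C(N)=O)cnn2cc(-c3ccccc3)cc12` is related to it by one change: the two compounds have the same atoms and bonds and differ only in configuration as drawn: 1 of 2 stereo elements differ; a stereocentre at a saturated chain carbon is drawn S in compound 3 and R in compound 4. The measured step that bears on this is a 29-fold higher number from compound 2 to compound 3 (1.46 log units; beyond the scatter), a large step in which both stereocentres are inverted. Compound 4 inverts only one of the stereocentres of compound 3, so part of that step is expected to be recovered, though how much is uncertain. In this assay, the expected change is a 5.0-fold lower number from compound 3 to compound 4 (0.70 log units; beyond the scatter), towards a lower number. Compound 4 is estimated at 400 nM, with an expected range from 100 nM to 1600 nM.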

Compound 4, half-maximal inhibitory concentration: 870 nM
For compound 4 the middle estimate is 2.2-fold (0.34 log units) below the measured one; low and high end bracket the measured number.
By their numbers in this assay, from the lowest: compound 2; then compound 1; then compound 4; then compound 3.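

In this assay, the two stereocentres do not count equally. Inverting one alone gives only a 2.3-fold lower number from compound 3 to compound 4 (0.36 log units; beyond the scatter), a modest step, whereas inverting the other alone gives a 12-fold higher number from compound 2 to compound 4 (1.09 log units; beyond the scatter), a large one. For the compounds shown here, the earlier pair inverted both centres at once and so could not separate them; these steps show that the single inversion separating compound 2 from compound 4 is enough to give a large step.

On these data alone, whether an amine in place of the chain hydroxyl would show the same dependence on configuration remains open. So does the effect of a longer chain in place of the methyl.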